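From pyrimidin-5-yl to pyrimidin-4-yl on the amide

The source may report more compounds than this note shows. Statements on the series, on what has been measured and on what is new or still open speak of the compounds shown alone.

Three amides sharing one core have so far been taken into an ADME assay on BEAS-2B cells (Homo sapiens) for cytotoxicity, read by fluorescence, with a stated time of 48 h (on this read-out lower numbers stand for higher toxicity in this test and higher numbers for lower toxicity in this test), with two numbers to show for it. Compound 1 (`Cc1ccoc1C(=O)N1CCCn2nc(C(=O)NCc3ccccc3)cc2C1`) gives 50000 nM and compound 2 (`Cc1ccoc1C(=O)N1CCCn2nc(C(=O)Nc3ccc(F)cc3F)cc2C1`) gives 5000 nM in this assay on the same scale. Compound 3 (`Cc1ccoc1C(=O)N1CCCn2nc(C(=O)Nc3cncnc3)cc2C1`) has no place on these numbers, since for compound 3 the entry reads "not determined" (no result reported): no result was reported for it and it offers no single value to start from.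

Compound 4 (`Cc1ccoc1C(=O)N1CCCn2nc(C(=O)Nc3ccncn3)cc2C1`) differs from compound 3 as follows: pyrimidin-4-yl in place of pyrimidin-5-yl on an amide-type nitrogen (the two have the same atoms, joined differently). Among the compounds with values here, the only measured step is a 10-fold lower number from compound 1 to compound 2 (1.00 log units; beyond the scatter) with 2,4-difluorophenyl in place of benzyl on an amide-type nitrogen. That step concerns the same kind of nitrogen, but it is not an exchange between the two pyrimidinyl groups. With compound 3 unmeasured, no size or direction of step from it can be expected on these data. The expectation therefore rests only on the span from compound 2 (5000 nM) to compound 1 (50000 nM). In this assay the estimate for compound 4 is 15000 nM with an expected range from 4000 nM to 50000 nM (values estimated, not measured).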

Compound 4, half-maximal cytotoxic concentration: 16600 nM
Beside the measured number, compound 4's estimate is 1.1-fold (0.04 log units) below it; measured number inside the range.
By their numbers in this assay, from the lowest: compound 2; then compound 4; then compound 1.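

In this assay, pyrimidin-4-yl on the amide-type nitrogen gives a 3.3-fold higher number from compound 2 to compound 4 (0.52 log units; beyond the scatter) and a 3.0-fold lower number from compound 1 to compound 4 (0.48 log units; beyond the scatter), which places compound 4 between the two earlier amides, with both steps beyond the usual scatter. This position therefore carries a third level of the read-out, and the earlier drop on going to 2,4-difluorophenyl is not repeated in full by every aromatic ring set on this nitrogen, as pyrimidin-4-yl recovers part of it while still not reaching the number of benzyl. No measurement shown explains why these three groups rank in this way.

As far as these compounds go, the step from compound 3 to compound 4 cannot be read, as compound 3 has no number, so it remains open whether moving from pyrimidin-5-yl to pyrimidin-4-yl changes the read-out at all. Also open, from the compounds shown here alone, is where plain phenyl, pyridin-3-yl or a saturated group such as cyclohexyl would fall on this nitrogen, and so whether the gap between compound 2 and compound 4 follows the fluorines, the ring nitrogens or both.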